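Series notes: hydroxy in place of methanesulfonamido

This account rests on a few compounds, and the source may have more. Where it says the series, first, only, none or still open, it means among the compounds named here.

Compound 1 `CSc1ccc(-c2c(C)nc3c(N4CC[C@@H](NC(C)=O)C4)cc(C)nn23)cc1`, compound 2 `COc1ccc(-c2c(C)nc3c(N4CC[C@@H](NS(C)(=O)=O)C4)cc(C)nn23)cc1OC` and compound 3 `COc1ccc(-c2c(C)nc3c(N4CC[C@@H](NS(=O)(=O)c5ccc(C(F)(F)F)cc5)C4)cc(C)nn23)cc1OC` share one core and have been run in an ADME assay on microsomes from liver (Homo sapiens) for metabolic stability, read by LC-MS, with NADPH named in the record, with a stated time of 60 min, tested at 1 uM, in the absence of a further agent; a lower number here means that less of the compound is left, a higher number that more of the compound is left. Compound 1 sits at the limit > 95%, which is a limit of the assay and not a number. Compound 2 likewise sits at the limit > 95%. Compound 3 also sits at the limit > 95%. Compound 2 therefore stands where every measured value stands, at the limit of > 95% in this assay, at which 3 of the 3 values shown sit. Among the measured compounds shown here, the one single-change step, a step that the two limits leave unreadable from compound 2 to compound 3, cannot be read. Compound 4 `COc1ccc(-c2c(C)nc3c(N4CC[C@@H](O)C4)cc(C)nn23)cc1OC` differs from compound 2 by hydroxy in place of methanesulfonamido on a saturated ring carbon. For the measured compounds named here, no measured step bears on this change, so no direction is expected beyond the scatter, though compound 4 may fall under the limit. Compound 4 is estimated at 85% in this assay, between 60% and 97%. This expectation means a step of a number at least 10 percentage points lower from compound 2 to compound 4 (that floor lies within the scatter).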

Compound 4, percent of the compound remaining: > 95%
Compound 4 gave a limit, no number (the forecaster's own chance of this, stated with the estimate: 40%); at least 10 percentage points between middle value and limit.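

Among the compounds shown here, compound 2 and compound 4 both sit at an assay limit, not at a number, so no step between them can be read: the limit of > 95% in this assay, at which 4 of the 4 values shown sit. As far as these compounds go, whether hydroxy in place of methanesulfonamido changes the percent of compound remaining stays open.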